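This account rests on a few compounds, and the source may have more. Where it says the series, first, only, none or still open, it means among the compounds named here.

Among the measured compounds shown here, in a functional assay on SPCA2 cells (Homo sapiens) for cytotoxicity, read by MTT assay, with a stated time of 2 days (on this read-out higher numbers stand for weaker inhibition and lower numbers for stronger inhibition), three compounds have numbers so far: compound 1 `Cc1ccc(CO/N=C2/C(c3c[nH]c4ccccc34)=Nc3ccccc32)cc1` (25400 nM), compound 2 `Fc1ccc(CO/N=C2/C(c3c[nH]c4ccccc34)=Nc3ccccc32)cc1` (25900 nM) and compound 3 `Clc1cccc(CO/N=C2/C(c3c[nH]c4ccc(Br)cc34)=Nc3ccc(Br)cc32)c1` (13500 nM). Neither compound 1 nor compound 3 lies beyond the usual scatter from compound 2. Compound 4 `Fc1ccc(CO/N=C2/C(c3c[nH]c4ccccc34)=Nc3ccccc32)c(Cl)c1` adds one atom to compound 2: chloro in place of hydrogen on an aromatic carbon This is chloro in place of hydrogen on an aromatic carbon, turning 4-fluorobenzyl into 2-chloro-4-fluorobenzyl. For the measured compounds named here, no measured step makes this exact change. The nearest guide is a 1.0-fold higher number from compound 1 to compound 2 (0.01 log units; within the scatter) for fluoro in place of methyl, which stays within the scatter. Compound 3 also carries a chloro group, and its value (13500 nM) stays within the scatter of compound 2. No step beyond the scatter is therefore expected, and the estimated size is a 1.3-fold lower number from compound 2 to compound 4 (0.11 log units; within the scatter) in this assay at most loosely. Compound 4 is estimated at 20000 nM (expected range 9000 nM to 42000 nM).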

Compound 4, half-maximal inhibitory concentration: 19500 nM
Compound 4: middle estimate off by 1.0-fold (0.01 log units), on the high side; low and high end bracket the measured number.
By their numbers in this assay, from the lowest: compounds 3, 4, 1 and 2 (each within the scatter of the next).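

In this assay a chloro group on the aromatic carbon ortho to a large group gives a 1.3-fold lower number from compound 2 to compound 4 (0.12 log units; within the scatter) and so stays within the scatter, showing that this position can carry a chlorine atom without a measurable shift. Exchanging 4-methylphenyl for 2-chloro-4-fluorophenyl gives a 1.3-fold lower number from compound 1 to compound 4 (0.11 log units; within the scatter) and also stays within the scatter, so two changes on this ring together still show no measurable shift. No measurement here offers an explanation for these results. Going by these compounds, whether an amine or a carboxylic acid at this same position would move the number beyond the scatter remains open.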